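The source may report more compounds than this note shows. Statements on the series, on what has been measured and on what is new or still open speak of the compounds shown alone.

The starting point is compound 1 `Cc1cc(S(=O)(=O)Nc2nc3ccsc3c(=O)n2Cc2ccccc2)c(S)cc1Cl`, which in a functional assay on HCT-116 cells (Homo sapiens) for inhibition (on this read-out lower numbers stand for stronger inhibition of growth and higher numbers for weaker inhibition of growth), gives 19200 nM. Compound 2 `Cc1cc(S(=O)(=O)Nc2nc3cc(-c4ccccc4)sc3c(=O)n2Cc2ccccc2)c(S)cc1Cl` carries a phenyl in place of a hydrogen on the shared core. In this assay compound 2 reaches only the limit of the assay, > 100000 nM, so its value is not a number. The step of an at least 5.2-fold higher number from compound 1 to compound 2 (0.71 log units; beyond the scatter) therefore cannot be sized exactly; it is known only that it reaches (the limit of > 100000 nM in this assay, at which 1 of the 2 values shown sits). On the numbers shown, compound 2 stands at the weak end, with only a limit to its name.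

Compound 3 `Cc1cc(S(=O)(=O)Nc2nc3cc(-c4ccc(Cl)cc4)sc3c(=O)n2Cc2ccccc2)c(S)cc1Cl` differs from compound 2 by chloro in place of hydrogen on an aromatic carbon. Going by the values given here, no measured step involves a chloro on this phenyl, so the only step that bears on the change is the one from hydrogen to phenyl, which was at least modest and went toward weaker inhibition of growth. Because compound 2 already sits at the limit of > 100000 nM in this assay, at which 1 of the 2 values shown sits, the change in compound 3 is expected to leave it there or move it little. In this assay the step that the limit leaves unreadable from compound 2 to compound 3 is therefore expected to lie within the scatter. Compound 3 is thus estimated at 150000 nM, with a range from 50000 nM to 500000 nM, and most likely reported only as a limit.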

Compound 3, concentration for 50% growth inhibition: > 100000 nM
Compound 3: no number, only a limit; the forecaster's own chance of this, stated with the estimate: 80%; the middle value lies beyond the limit too.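

In this assay, compound 3 gives > 100000 nM, which is a limit of the assay and not a number. Set against hydrogen at this position on the shared core, the 4-chlorophenyl group gives an at least 5.2-fold higher number from compound 1 to compound 3 (0.71 log units; beyond the scatter), so a second aromatic group now goes the same way as the plain phenyl, toward weaker inhibition of growth. What chloro in place of hydrogen on the phenyl does by itself cannot be read, because the values on both sides of that step stop at the same limit: the limit of > 100000 nM in this assay, at which 2 of the 3 values shown sit.

The compounds shown leave open whether any group on this phenyl can bring the read-out back into the measurable range, since only chloro is shown there and a carboxylic acid or an amine in its place might behave differently. They also leave open whether a smaller group than phenyl at this position of the core, such as a methyl or a short amine chain, would stay close to compound 1, which gives 19200 nM, or would also move toward weaker inhibition of growth.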